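Trifluoromethyl for Methoxy on Two Related Cores

This account rests on a few compounds, and the source may have more. Where it says the series, first, only, none or still open, it means among the compounds named here.

The measured compounds and their values:
compound 1 `CCOC1=C(/C(C)=N/OCC(=O)Nc2ccc(OC)cc2)N(C)S(=O)(=O)c2ccccc21`: > 20000 nM
compound 2 `CCOC1=C(/C(C)=N/OCC(=O)Nc2ccc(C(F)(F)F)cc2)N(C)S(=O)(=O)c2ccccc21`: 16700 nM
compound 3 `COc1ccc(NC(=O)CO/N=C(\C)C2=C(O)c3ccccc3S(=O)(=O)N2C)cc1`: > 20000 nM

All three were tested in a functional assay on THP-1 cells (Homo sapiens) for inhibition, read by ELISA, with stated times of 2 h and 48 h; on this read-out higher numbers stand for weaker inhibition and lower numbers for stronger inhibition. For compound 1 this assay gives only a limit, > 20000 nM. For compound 3 it likewise gives only a limit, > 20000 nM. Compound 2 gives a number, 16700 nM. Compound 2 differs from compound 1 by trifluoromethyl in place of methoxy on an aromatic carbon, and this produced an at least 1.1-fold lower number from compound 1 to compound 2 (0.07 log units; that floor lies within the scatter). Compound 3 differs from compound 1 in the core, by hydrogen in place of ethyl on an oxygen on an unsaturated carbon, and the step is a step that the two limits leave unreadable from compound 1 to compound 3.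

Compound 4 `C/C(=N\OCC(=O)Nc1ccc(C(F)(F)F)cc1)C1=C(O)c2ccccc2S(=O)(=O)N1C` carries the same change relative to compound 3 that compound 2 carries relative to compound 1, namely (trifluoromethyl in place of methoxy on an aromatic carbon). The earlier step is barely readable because of the limit of > 20000 nM in this assay, at which 2 of the 3 values shown sit. Compound 4 is therefore expected to land near the same limit, with an estimated step of a number no higher from compound 3 to compound 4 (the limit leaves the size open) from compound 3. The expected value for compound 4 is 20000 nM, within an estimated range of 8000 nM to 50000 nM.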

Compound 4, half-maximal inhibitory concentration: > 20000 nM
Compound 4: no number, only a limit; the forecaster's own chance of this, stated with the estimate: 60%; the middle value sits exactly at the limit.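

In this assay compound 4 gives only a limit, > 20000 nM. Within the data shown here, the steps that join two limits cannot be read, so the change from 4-methoxyphenyl to 4-(trifluoromethyl)phenyl on the core of compound 3 can be neither confirmed nor ruled out as repeating on that core what it did on the core of compound 1, because the values crowd at one edge of the read-out: the limit of > 20000 nM in this assay, at which 3 of the 4 values shown sit. The one new step that can be read, an at least 1.1-fold higher number from compound 2 to compound 4 (0.07 log units; that floor lies within the scatter), gives only a floor, so it shows no firm effect of hydrogen in place of ethyl on the oxygen and does not show that the two cores behave alike.

The compounds shown leave open how either core responds to this change once values fall clear of that limit. As far as these compounds go, whether an amine or a carboxylic acid on the same aromatic carbon, or a longer chain in place of the ethyl on the oxygen, would bring such values also remains open.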